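Swapping Bromo for Methoxy on a Second Core

The compounds below may be only part of what the source reports. "The series", "measured", "known", "first", "only" and "open" are said of these compounds alone.

Compound 1 `COC(=O)[C@@]1(C)CC[C@@H]2C3=C1CC[C@@H](C)[C@]3(C)C[C@@H]1c3cc(Br)ccc3N[C@H]21` carries a bromo group on an aromatic carbon, and in a functional assay on A549 cells (Homo sapiens) for inhibition, read by sulforhodamine B assay, with a stated time of 48 h (on this read-out higher numbers stand for weaker inhibition of growth and lower numbers for stronger inhibition of growth), compound 1 gives 40000 nM. Compound 2 `COC(=O)[C@@]1(C)CC[C@@H]2C3=C1CC[C@@H](C)[C@]3(C)C[C@@H]1c3cc(OC)ccc3N[C@H]21` differs from it by one change, (methoxy in place of bromo on an aromatic carbon), and in this assay compound 2 gives 22000 nM. The step between them, a 1.8-fold lower number from compound 1 to compound 2 (0.26 log units; within the scatter), is small enough that the two compounds cannot be told apart on this read-out.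

Compound 3 `COC(=O)[C@@]1(C)CC[C@@H]2C3=C1CC[C@@H](C)[C@]3(C)Cc1c2[nH]c2ccc(Br)cc12` is built on a different core; the difference between the two cores is not broken down here. In this assay compound 3 gives 17000 nM. Its number lies close to that of compound 2 and is a larger distance from that of compound 1.

Compound 4 `COC(=O)[C@@]1(C)CC[C@@H]2C3=C1CC[C@@H](C)[C@]3(C)Cc1c2[nH]c2ccc(OC)cc12` has not yet been measured. It differs from compound 3 by methoxy in place of bromo on an aromatic carbon, the same change that separates compound 1 from compound 2, at the same place. Among the compounds with values here, the only guide to its effect is that one pair, so the expected step here is a 1.4-fold lower number from compound 3 to compound 4 (0.15 log units; within the scatter), because a 1.8-fold lower number from compound 1 to compound 2 (0.26 log units; within the scatter) was itself within the usual scatter. On that basis compound 4 is estimated to give 12000 nM in this assay, most likely somewhere between 5000 nM and 30000 nM. Whether the second core answers the change in the same way is something only the measurement can settle.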

Compound 4, concentration for 50% growth inhibition: 7700 nM
Compound 4: middle estimate off by 1.6-fold (0.19 log units), on the high side; the range from low to high includes it.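

In this assay, putting methoxy in place of bromo on the second core gives a 2.2-fold lower number from compound 3 to compound 4 (0.34 log units; beyond the scatter), a modest step that clears the usual scatter of the measurement. Set beside the same change on the core of compound 1, this step runs in the same direction, and the two steps cannot be told apart in size: the same change on two cores in this assay, a 1.8-fold lower number (0.26 log units; within the scatter) from compound 1 to compound 2 and a 2.2-fold lower number (0.34 log units; beyond the scatter) from compound 3 to compound 4, 1.2-fold (0.08 log units) apart, within the scatter of two such steps

On these two pairs, then, the change carries over from one core to the other, with the number falling on both and by a similar amount, but this is a thin base: the step on the core of compound 1 is itself within the scatter, two pairs say nothing about any further core, and nothing here explains why methoxy and bromo give different numbers.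

The compounds shown carry only bromo or methoxy at this aromatic carbon, so it stays open how a group such as an amine, a carboxylic acid or a longer chain would behave there on either core. From the compounds shown here alone, whether the two cores would again answer alike with such groups, or in a different cell line, also remains open.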